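Ethynyl for Methyl: Three Weak Compounds, One Forecast

The source may hold more compounds than are shown below. What is called first, only, known or untested is meant among the compounds shown, and "the series" means these compounds.

Compound 1 `C#CCN(Cc1ccc2nc(C)nc(O)c2c1)c1ccccc1` — in a functional assay on L1210 cells (Mus musculus) for inhibition (on this read-out lower numbers stand for stronger inhibition and higher numbers for weaker inhibition), compound 1 gives > 6500 nM, a limit of the assay.
Compound 2 `C#CCN(Cc1ccc2nc(C)nc(O)c2c1)c1cccc(C)c1` — compound 2 gives > 5000 nM, a limit of the assay.
Compound 3 `C#CCN(Cc1ccc2nc(C)nc(O)c2c1)c1cccc(CO)c1` — compound 3 gives 48000 nM.

Compound 2 stands at a limit, so no number is known for it. Compound 1 likewise sits at a limit. Only compound 3 gives a number, and it is a weak one. The three measured steps, a step that the two limits leave unreadable from compound 1 to compound 2, a step that the limit leaves unreadable from compound 1 to compound 3 and a step that the limit leaves unreadable from compound 2 to compound 3, are all left unreadable by these limits, so none of them gives a size that could be carried over.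

Compound 4 `C#CCN(Cc1ccc2nc(C)nc(O)c2c1)c1cccc(C#C)c1` differs from compound 2 by ethynyl in place of methyl on an aromatic carbon. For the measured compounds named here, no measured step concerns ethynyl in place of methyl on an aromatic carbon, and the measured steps that exist have no readable size. What can be said is that all three measured compounds are weak in this assay.

Compound 4 is therefore expected to remain weak, and it is estimated at 20000 nM, with a range from 5000 nM to 80000 nM. This corresponds to an expected step that the limit leaves unreadable from compound 2 to compound 4 in this assay, which rests only on the weakness shared by compound 1, compound 2 and compound 3.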

Compound 4, half-maximal inhibitory concentration: > 2400 nM
Compound 4 ended at the assay's limit; the forecaster's own chance of this, stated with the estimate: 40%; the middle value lies beyond the limit too.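

In this assay compound 4 gives > 2400 nM, a limit of the assay and not a number. For the compounds shown here, no step to compound 4 from compound 1, compound 2 or compound 3 can be read. The compounds shown leave open whether ethynyl in place of methyl on an aromatic carbon changes inhibition at all.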